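A few compounds are considered here, and "the series" means these few. Any claim that something is new, unique, unknown or untested is made for them only; others in the source may bear on it.

Measured in an ADME assay on MDBK cells (Bos taurus) for cytotoxicity; on this read-out lower numbers stand for higher toxicity in this test and higher numbers for lower toxicity in this test:
- Compound 1 `COc1ccc(Cn2ccc3nc(-c4ccccc4)nc-3c2)cc1`: > 100000 nM
- Compound 2 `CCn1ccc2nc(-c3ccccc3)nc-2c1`: > 100000 nM

Compound 2 stands at > 100000 nM, which is a limit of the assay and not a number. Compound 1 gives > 100000 nM, also a limit. That is the whole picture so far: the limit of > 100000 nM in this assay, at which 2 of the 2 values shown sit. For the measured compounds named here, the one measured step, a step that the two limits leave unreadable from compound 1 to compound 2, therefore offers no size to build on.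

Compound 3 `C(=C/c1ccccc1)\Cn1ccc2nc(-c3ccccc3)nc-2c1` has 2-phenylethenyl in place of methyl on a saturated chain carbon bound to an aromatic nitrogen. Going by the values given here, the larger 4-methoxyphenyl-bearing group of compound 1, with its > 100000 nM, gives the only guide, so no step beyond the scatter is expected in this assay. The expected step is a number no higher from compound 2 to compound 3 (the limit leaves the size open), and a limit is again the likely report. For compound 3 the estimated value is 100000 nM, with an expected range of 30000 nM to 200000 nM.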

Compound 3, half-maximal cytotoxic concentration: 78000 nM
Estimate against measurement, compound 3: 1.3-fold (0.11 log units) above; measured number inside the range.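

In this assay, for the compounds shown here, compound 3 gives 78000 nM, the only actual number so far for a group on a saturated chain carbon bound to an aromatic nitrogen. Putting 2-phenylethenyl at this place gives an at least 1.2-fold lower number from compound 2 to compound 3 (0.10 log units; that floor lies within the scatter), and the comparison with the 4-methoxyphenyl group gives an at least 1.2-fold lower number from compound 1 to compound 3 (0.10 log units; that floor lies within the scatter). The true size of both steps cannot be told, because the other two values are limits and not numbers: the limit of > 100000 nM in this assay, at which 2 of the 3 values shown sit.

The step from compound 1 to compound 2 cannot be read, so methyl and 4-methoxyphenyl cannot be ranked against each other. Also open, as far as these compounds go, are whether the double bond or the added aromatic ring of 2-phenylethenyl matters here, and whether an amine, a carboxylic acid or a longer saturated chain at this place would give a number beyond the scatter.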